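A few compounds are considered here, and "the series" means these few. Any claim that something is new, unique, unknown or untested is made for them only; others in the source may bear on it.

Working notes on a small set of compounds tested in an assay on HEK293 cells for agonist activity at transient receptor potential cation channel subfamily M member 8 (Homo sapiens), read by fluorescence and calcium flux, with a stated time of 15 min; a lower number here means that less compound is needed, a higher number that more compound is needed for the effect. Compound 1 `CCN(Cc1cccn1C)C(=O)COc1ccc(C)cc1` gives 21300 nM in this assay. Compound 2 `Cc1ccc(OCC(=O)N(Cc2cccs2)c2ccnn2C)cc1` gives 422 nM, and compound 3 `CCN(Cc1cccs1)C(=O)COc1cccc(C)c1` gives 97 nM. Among the three numbers, compound 2 stands second highest: compound 3 is the nearest, with the lower number, and compound 1 the furthest, with the higher number, and both gaps lie beyond the scatter. No two of these measured compounds differ in one place only, so no single step can be read from them.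

Compound 4 `Cc1ccc(OCC(=O)N(Cc2cccs2)c2nccn2C)cc1` has not yet been measured. It differs from compound 2 in one place: 1-methyl-1H-imidazol-2-yl in place of 1-methyl-1H-pyrazol-5-yl on an amide-type nitrogen. The two have the same atoms, joined differently. Among the measured compounds shown here, with no comparable step among the measured compounds, the size of the step in this assay cannot be read from data; the expectation is a step of a 1.1-fold higher number from compound 2 to compound 4 (0.03 log units; within the scatter), in no settled direction and not beyond the scatter. On that basis compound 4 is estimated at 450 nM in this assay, with a range from 150 nM to 1500 nM.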

Compound 4, half-maximal effective concentration: 1790 nM
For compound 4 the middle estimate is 4.0-fold (0.60 log units) below the measured one; measured number above the stated range.
By their numbers in this assay, from the lowest: compound 3; then compound 2; then compound 4; then compound 1.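

Among the compounds shown here, the change from 1-methyl-1H-pyrazol-5-yl to 1-methyl-1H-imidazol-2-yl on the amide-type nitrogen gives a 4.2-fold higher number from compound 2 to compound 4 (0.63 log units; beyond the scatter) in this assay and is the first single-place comparison. This position therefore distinguishes two groups with the same atoms, joined differently, and the same counts of hydrogen-bond donors and acceptors, so those counts alone do not settle the value at this position in this pair. Nothing at hand gives a measured property that would explain the difference between these two groups.

Compound 1 and compound 3 each differ from compound 2 and compound 4 in more than one place, so they cannot show whether this step holds on another background. As far as these compounds go, how this position would respond to a phenyl group or a longer chain such as n-butyl remains open.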